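This account rests on a few compounds, and the source may have more. Where it says the series, first, only, none or still open, it means among the compounds named here.

Four compounds share a nucleoside-like core carrying a long saturated chain on a nitrogen attached to an aromatic ring. Compound 1 is `CCCCCCCCCCNc1ccn([C@H]2C[C@H](O)[C@@H](CO)O2)c(=O)n1` and compound 2 is `CCCCCCCCCCCCNc1ccn([C@H]2C[C@H](O)[C@@H](CO)O2)c(=O)n1`. In an ADME assay on A549 cells (Homo sapiens) for cytotoxicity, read by MTT assay (a lower number here means that less compound is tolerated, a higher number that more compound is tolerated), compound 1 gives 200000 nM, and compound 2 gives 100000 nM; the change between them, (ethyl in place of hydrogen on a saturated chain carbon, ten or more bonds along the chain from a nitrogen on an aromatic ring), gave a 2.0-fold lower number from compound 1 to compound 2 (0.30 log units; within the scatter).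

Compound 3 is `CCCCCCCCCCNc1nc(=O)n([C@H]2C[C@H](OC(=O)OCCOCCOCCO)[C@@H](CO)O2)cc1C`, and its core differs from the core of compound 1 in more than one place; that difference between the two cores is not broken down here. In this assay compound 3 gives 90000 nM, which is within the scatter of the number for compound 2, while the gap to compound 1 is beyond it.

Compound 4 is `CCCCCCCCCCCCNc1nc(=O)n([C@H]2C[C@H](OC(=O)OCCOCCOCCO)[C@@H](CO)O2)cc1C`, not yet measured. It stands to compound 3 exactly as compound 2 stands to compound 1: the change is ethyl in place of hydrogen on a saturated chain carbon, ten or more bonds along the chain from a nitrogen on an aromatic ring, the same change as before, made at the same kind of place. Going by the values given here, the only guide to its size is the single earlier instance, which lay within the scatter, so the expectation is a step of similar size, a 1.6-fold lower number from compound 3 to compound 4 (0.21 log units; within the scatter), resting on the fact that compound 3 gives 90000 nM and that the earlier instance gave a 2.0-fold lower number from compound 1 to compound 2 (0.30 log units; within the scatter). With a single precedent the uncertainty is wide. The estimated value for compound 4 in this assay is 55000 nM, expected to fall between 25000 nM and 120000 nM.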

Compound 4, half-maximal cytotoxic concentration: 90000 nM
Estimate against measurement, compound 4: 1.6-fold (0.21 log units) below; measured number inside the range.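

Putting ethyl in place of hydrogen on the chain of compound 3 gave no change at the digits printed from compound 3 to compound 4 (within the scatter) in this assay, so on this second core the change again leaves the number within the normal spread of repeated measurements. Set side by side, the two instances do not differ by more than that spread allows: the same change on two cores in this assay, a 2.0-fold lower number (0.30 log units; within the scatter) from compound 1 to compound 2 and no change at the digits printed (within the scatter) from compound 3 to compound 4, 2.0-fold (0.30 log units) apart, within the scatter of two such steps. This shows that the change behaves alike on these two cores in this cell test, and that a step seen on one core was a fair guide to the other; it does not show that the change has a real effect of any fixed size, since neither step rises above the scatter, and two cores say nothing about a third.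

From the compounds shown here alone, what remains open is whether any chain change moves the number beyond the scatter, for instance a much longer chain or a much shorter one. Going by these compounds, it is also open whether a group of another kind at the far end of the chain, such as an amine or a carboxylic acid, would leave the number as undisturbed as ethyl does here.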